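A few compounds are considered here, and "the series" means these few. Any claim that something is new, unique, unknown or untested is made for them only; others in the source may bear on it.

Two compounds sharing one core, compound 1 `OC[C@H]1O[C@@H](n2cnc3c(NCc4ccccc4F)ncnc32)[C@H](O)[C@@H]1O` and compound 2 `OC[C@H]1O[C@@H](n2cnc3c(NCc4ccccc4OC(F)F)ncnc32)[C@H](O)[C@@H]1O`, have been taken into a functional assay on G-361 cells (Homo sapiens) for antiproliferative activity, with a stated time of 72 h; a higher number here means a weaker inhibitor, a lower number a stronger inhibitor. There compound 1 has the entry "not determined" (no result reported), so it offers no number for comparison. Compound 2 gives > 166000 nM, which is a limit of the assay and not a number. Among the measured compounds shown here, the only firm reading for compound 2 is therefore (the limit of > 166000 nM in this assay, at which 1 of the 2 values shown sits).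

Compound 3 `OC[C@H]1O[C@@H](n2cnc3c(NCc4cccc(C(F)(F)F)c4)ncnc32)[C@H](O)[C@@H]1O` carries 3-(trifluoromethyl)phenyl in place of 2-(difluoromethoxy)phenyl on a saturated chain carbon bound to a nitrogen on an aromatic ring. For the measured compounds named here, no measured step exists to show how large such a change might be in this assay. A modest move towards stronger inhibition is expected, though compound 3 may also return only a limit. The expected change is an at least 2.0-fold lower number from compound 2 to compound 3 (0.31 log units; beyond the scatter). For compound 3 the estimated value is 80000 nM, with an expected range from 12000 nM to 200000 nM.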

Compound 3, half-maximal inhibitory concentration: > 166000 nM
Compound 3 ended at the assay's limit (the forecaster's own chance of this, stated with the estimate: 55%); middle value at least 2.0-fold (0.31 log units) away from the limit.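

Compound 2 and compound 3 both sit at a limit of this assay and not at a number, so the step between them cannot be read: the limit of > 166000 nM in this assay, at which 2 of the 3 values shown sit.

The compounds shown leave open how strongly either one inhibits, and whether 3-(trifluoromethyl)phenyl and 2-(difluoromethoxy)phenyl differ at all in this assay.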